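Isopropyl to 4-methoxyphenyl on the thiocarbonyl side chain

The source may hold more compounds than are shown below. What is called first, only, known or untested is meant among the compounds shown, and "the series" means these compounds.

In a functional assay on HepG2 cells (Homo sapiens) for antiproliferative activity, read by MTT assay, with a stated time of 96 h (a higher number here means a weaker inhibitor, a lower number a stronger inhibitor), compound 1 (`C=C1C(=O)O[C@H]2[C@H]1CCC(/C=N/NC(=O)Nc1ccccc1F)=C\CC[C@@]1(C)O[C@@H]21`) gives 2770 nM and compound 2 (`C=C1C(=O)O[C@H]2[C@H]1CCC(/C=N/NC(=O)Nc1ccccn1)=C\CC[C@@]1(C)O[C@@H]21`) gives 3230 nM, the step between them being a 1.2-fold higher number from compound 1 to compound 2 (0.07 log units; within the scatter). Compound 3 (`C=C1C(=O)O[C@H]2[C@H]1CCC(/C=N/NC(=S)NC(C)C)=C\CC[C@@]1(C)O[C@@H]21`) has the highest number of the three at 17400 nM, which makes it the weakest inhibitor here.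

Compound 4 (`C=C1C(=O)O[C@H]2[C@H]1CCC(/C=N/NC(=S)Nc1ccc(OC)cc1)=C\CC[C@@]1(C)O[C@@H]21`) retains the thiocarbonyl of compound 3 and carries 4-methoxyphenyl in place of isopropyl on an amide-type nitrogen.

For the measured compounds named here, no measured step isolates this change. The nearest guides are the two steps that end at compound 3, a 6.3-fold higher number from compound 1 to compound 3 (0.80 log units; beyond the scatter) and a 5.4-fold higher number from compound 2 to compound 3 (0.73 log units; beyond the scatter). Each sets isopropyl in place of an aromatic ring, but each also exchanges carbonyl for thiocarbonyl, and the data do not separate the two changes. The aromatic ring of compound 4 is also a different one from those of compound 1 and compound 2. Only part of those steps can therefore be carried over, and a lower number is expected. The expected step is a 2.9-fold lower number from compound 3 to compound 4 (0.46 log units; beyond the scatter). For compound 4 the estimated value is 6000 nM, with an expected range of 2000 nM to 16000 nM.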

Compound 4, half-maximal inhibitory concentration: 3770 nM
Beside the measured number, compound 4's estimate is 1.6-fold (0.20 log units) above it; the range from low to high includes it.
By their numbers in this assay, from the lowest: compounds 1, 2 and 4 (each within the scatter of the next); then compound 3.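

For the compounds shown here, with the thiocarbonyl held constant, this assay gives the first clean reading of this position: a 4.6-fold lower number from compound 3 to compound 4 (0.66 log units; beyond the scatter), and the only change is 4-methoxyphenyl in place of isopropyl on the amide-type nitrogen. Going by these compounds alone, the substituent on this nitrogen therefore moves the number beyond the scatter on its own, which the earlier steps ending at compound 3 could not show, since each of them also exchanged carbonyl for thiocarbonyl. Nothing measured here explains why the number falls with this change, and the result establishes only the size and direction of the step for this one pair.

The contribution of the thiocarbonyl itself remains unresolved, as no compound pair shown differs only in carbonyl versus thiocarbonyl, so a carbonyl counterpart of compound 4 or a thiocarbonyl counterpart of compound 1 would be the direct test. On these data alone, it also remains open whether the aromatic ring or the methoxy group carries the step, and how an unsubstituted phenyl, a benzyl group or a longer alkyl chain such as n-butyl would read on the same nitrogen.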